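The compounds below may be only part of what the source reports. "The series", "measured", "known", "first", "only" and "open" are said of these compounds alone.

Among the compounds with values here, in an assay on CHO cells for displacement of a labelled ligand from 5-hydroxytryptamine receptor 1B (Homo sapiens) (on this read-out higher numbers stand for weaker inhibition and lower numbers for stronger inhibition), compound 1 `CN(Cc1ccco1)C1CCN(CCCc2c[nH]c3ccc(-n4cnnc4)cc23)CC1` gives 89 nM, the lowest of the two numbers known here. Compound 2 `CNS(=O)(=O)Cc1ccc2[nH]cc(CCCN3CCC(N[C@H](C)c4ccccc4)CC3)c2c1` gives 260 nM in this assay, a gap from compound 1 that lies beyond the scatter. Compound 3 `CN(Cc1cccs1)C1CCN(CCCc2c[nH]c3ccc(-n4cnnc4)cc23)CC1` has not been measured and differs from compound 1 in one place: thiophen-2-yl in place of furan-2-yl on a saturated chain carbon bound to an amine nitrogen. Within the data shown here, no measured pair shows this exchange, so its effect is unknown. The expected step of a 1.1-fold lower number from compound 1 to compound 3 (0.05 log units; within the scatter) is small, with no direction beyond the scatter. Compound 3 is therefore expected to give 80 nM, in a range of 35 nM to 180 nM, in this assay.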

Compound 3, half-maximal inhibitory concentration: 140 nM
Compound 3: the middle estimate sits 1.8-fold (0.24 log units) below what was measured; low and high end bracket the measured number.
By their numbers in this assay, from the lowest: compounds 1, 3 and 2 (each within the scatter of the next, the first and the last beyond it).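

Thiophen-2-yl in place of furan-2-yl on a saturated chain carbon bound to an amine nitrogen gives the first direct reading at this position in this assay: a 1.6-fold higher number from compound 1 to compound 3 (0.20 log units; within the scatter). The two five-membered aromatic rings, one carrying oxygen and one sulfur, cannot be told apart here, so this position accepts either one on the shared core. No available data bear on the reason for this result.

Open, from the compounds shown here alone, is how this position responds to a larger ring such as phenyl or pyridin-2-yl. Also open, going by these compounds, is whether the same exchange reads alike on a shorter chain.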